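Trimming one methoxy group: what to expect for compound 3

The source may report more compounds than this note shows. Statements on the series, on what has been measured and on what is new or still open speak of the compounds shown alone.

Measured so far:
compound 1, `COc1ccc(-c2cc(/C=C/C(=O)c3ccc(N)cc3)[nH]n2)cc1`: 88%
compound 2, `COc1cc(-c2cc(/C=C/C(=O)c3ccc(N)cc3)[nH]n2)cc(OC)c1OC`: 82%

In a functional assay on SF-295 cells (Homo sapiens) for cytotoxicity, read by sulforhodamine B assay, with a stated time of 48 h, tested at 1 uM (on this read-out lower numbers stand for a stronger effect and higher numbers for a weaker effect at the one concentration tested), compound 1 gives 88% and compound 2 gives 82%. Compound 2 carries the lower of the two numbers, but the gap to compound 1 lies within the scatter, so the two cannot be told apart. Compound 3, `COc1ccc(-c2cc(/C=C/C(=O)c3ccc(N)cc3)[nH]n2)cc1OC`, has not yet been measured. It differs from compound 2 by hydrogen in place of methoxy on an aromatic carbon. Because compound 1 shows 88% and compound 2 shows 82%, the step from compound 2 to compound 3 is expected to be small, with no change beyond the scatter; the expected size is a number 3 percentage points higher from compound 2 to compound 3 (within the scatter). Compound 3 is therefore estimated at 85%, with a range from 72% to 96%.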

Compound 3, a percentage reported as activity, at one concentration (the size of the read-out at that concentration, not a potency): 87%
Estimate against measurement, compound 3: 2 percentage points below, and the stated range covers the measured number.
By their numbers in this assay, from the lowest: compounds 2, 3 and 1 (each within the scatter of the next).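

In this assay hydrogen in place of methoxy gives a number 5 percentage points higher from compound 2 to compound 3 (within the scatter) and methoxy in place of hydrogen gives a number 1 percentage points lower from compound 1 to compound 3 (within the scatter) on an aromatic carbon. Both steps stay within the scatter, so a single methoxy group, added or removed here, makes no readable difference at the one concentration tested. No measurement shown explains these small steps. Still open, on these data alone, is whether a different group at this place, such as an amine, a hydroxyl group or a carboxylic acid, would shift the read-out beyond the scatter.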